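The source may hold more compounds than are shown below. What is called first, only, known or untested is meant among the compounds shown, and "the series" means these compounds.

Measured compounds in the series:

Compound 1 `COc1ccc(OC)c(C(c2c[nH]c3ccc(Br)cc23)c2c[nH]c3ccc(Br)cc23)c1`: 5100 nM
Compound 2 `Brc1ccc2[nH]cc(C(c3ccc4ccccc4c3)c3c[nH]c4ccc(Br)cc34)c2c1`: 4300 nM
Compound 3 `Clc1ccc(C(c2c[nH]c3ccc(Br)cc23)c2c[nH]c3ccc(Br)cc23)cc1`: 4800 nM

All three were run in a functional assay on HeLa cells (Homo sapiens) for inhibition, read by MTT assay, with a stated time of 48 h; on this read-out lower numbers stand for stronger inhibition and higher numbers for weaker inhibition. Compound 1 gives the highest number of the three, yet its gap to compound 3 a 1.1-fold lower number from compound 1 to compound 3 (0.03 log units; within the scatter) and to compound 2 a 1.2-fold lower number from compound 1 to compound 2 (0.07 log units; within the scatter) both sit within the scatter, so no order among them can be read. The step between compound 2 and compound 3 a 1.1-fold higher number from compound 2 to compound 3 (0.05 log units; within the scatter) is likewise within the scatter. In each of these steps one aromatic group on the saturated chain carbon bound to two aromatic carbons is swapped for another, and the read-out does not move.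

Compound 4 `CCCCCCCC(c1c[nH]c2ccc(Br)cc12)c1c[nH]c2ccc(Br)cc12` is not yet measured. Its change from compound 1 is heptyl in place of 2,5-dimethoxyphenyl on a saturated chain carbon bound to two aromatic carbons. This differs from the measured steps in that the entering group has no ring. None of the three steps above covers a swap of an aromatic group for a chain at this position, so they bear only indirectly: they show the shared core tolerates different groups here without shifting the number. The step from compound 1 to compound 4 is therefore expected to be small, a 1.1-fold higher number from compound 1 to compound 4 (0.03 log units; within the scatter), with a wide range to allow for the untested type of change. Compound 4 is estimated at 5500 nM, between 2200 nM and 14000 nM.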

Compound 4, half-maximal inhibitory concentration: 1300 nM
For compound 4 the middle estimate is 4.2-fold (0.63 log units) above the measured one, and the stated range ends above it.
By their numbers in this assay, from the lowest: compound 4; then compounds 2, 3 and 1 (each within the scatter of the next).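

In this assay this position is no longer silent: heptyl in place of an aromatic group gives a 3.9-fold lower number from compound 1 to compound 4 (0.59 log units; beyond the scatter) and a 3.7-fold lower number from compound 3 to compound 4 (0.57 log units; beyond the scatter) and also a 3.3-fold lower number from compound 2 to compound 4 (0.52 log units; beyond the scatter) as the three steps to compound 4, whereas swaps of one aromatic group for another gave no readable change. Among these four compounds, the read-out therefore separates the entering group with no ring from the three groups with an aromatic ring, and compound 4 is the most potent, with no compound going against this split. No supporting data bear on why the chain gives the lower number.

With heptyl as the only chain, the compounds shown cannot separate the effect of chain length from that of losing the aromatic ring; a shorter or longer chain, or a cyclohexyl group, would address this. Also open, from the compounds shown here alone, is whether the chain tolerates a terminal amine or carboxylic acid, and whether the lower number holds on any cell type other than the one tested here.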